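Chloro to fluoro swap on the aryl ring

The source may hold more compounds than are shown below. What is called first, only, known or untested is meant among the compounds shown, and "the series" means these compounds.

Measured so far:
compound 1, `Cc1nnc(SCC(=O)N/N=c2/scc(-c3ccc(F)cc3)n2-c2ccccc2)s1`, 50.1%
compound 2, `O=C(CSc1nnnn1-c1ccccc1)N/N=c1/scc(-c2ccc(Cl)cc2)n1-c1ccccc1`, 62.3%

In a functional assay on C6 cells (Rattus norvegicus) for cytotoxicity, read by MTT assay, with a stated time of 24 h, tested at 25 ug/mL (on this read-out higher numbers stand for a weaker effect at the one concentration tested and lower numbers for a stronger effect), compound 2 gives 62.3%, the highest of the two numbers recorded, and the nearest value is that of compound 1, which lies lower by a margin beyond the usual scatter. Among the compounds with values here, compound 1 and compound 2 differ in more than one place, so no single-point step between measured compounds exists to draw on.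

Compound 3, `O=C(CSc1nnnn1-c1ccccc1)N/N=c1/scc(-c2ccc(F)cc2)n1-c1ccccc1`, is compound 2 with fluoro in place of chloro on an aromatic carbon, that is 4-chlorophenyl changed to 4-fluorophenyl, while the rest of the molecule is kept. Within the data shown here, no measured step covers this exchange. Given that compound 1, which also carries fluoro on that ring, gives 50.1%, a modest move downward in this assay is expected, but a result within the scatter is also plausible. The step from compound 2 to compound 3 is estimated at a number 6.3 percentage points lower from compound 2 to compound 3 (within the scatter). Compound 3 is expected to give about 56%, in a range of 42% to 70%.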

Compound 3, a percentage reported as activity, at one concentration (the size of the read-out at that concentration, not a potency): 49.3%
The estimate for compound 3 lay 6.7 percentage points above the measured number, and the stated range covers the measured number.
By their numbers in this assay, from the lowest: compounds 3 and 1 (each within the scatter of the next); then compound 2.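

In this assay, within the data shown here, fluoro in place of chloro on an aromatic carbon para to a large group gives a number 13 percentage points lower from compound 2 to compound 3 (beyond the scatter), the first single-place reading at this position, and it shows that this halogen exchange alone moves the read-out by more than the scatter. With 4-fluorophenyl held constant, 1-phenyl-1H-tetrazol-5-yl in place of 5-methyl-1,3,4-thiadiazol-2-yl on the sulfur gives a number 0.8 percentage points lower from compound 1 to compound 3 (within the scatter), so this read-out does not separate these two groups on the sulfur. Nothing in the data available here bears on the cause of either step.

Still open, as far as these compounds go, is whether the halogen step carries over when 5-methyl-1,3,4-thiadiazol-2-yl sits on the sulfur. Also open, from the compounds shown here alone, is how the read-out responds at this ring position to a group such as bromo, methoxy or an amine.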